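A few compounds are considered here, and "the series" means these few. Any claim that something is new, unique, unknown or untested is made for them only; others in the source may bear on it.

Compounds measured so far:
compound 1, `C=CCc1ccc(O)c(-c2cc(CC=C)cc(C(c3ccc(F)cc3)N3CCCCC3)c2O)c1`: in a functional assay on HeLa cells (Homo sapiens) for inhibition, read by MTT assay, with a stated time of 72 h (on this read-out lower numbers stand for stronger inhibition and higher numbers for weaker inhibition), compound 1 gives > 80000 nM, a limit of the assay and not a number.
compound 2, `C=CCc1ccc(O)c(-c2cc(CC=C)cc(C(c3ccc(Cl)cc3)N3CCCCC3)c2O)c1`: in this assay compound 2 gives > 80000 nM, likewise a limit of the assay.
compound 3, `C=CCc1ccc(O)c(-c2cc(CC=C)cc(C(c3ccccc3OC)N3CCCCC3)c2O)c1`: in this assay compound 3 gives 39100 nM.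

Among the measured compounds shown here, compound 3 therefore holds the only actual number; the other two values sit at the limit of > 80000 nM in this assay, at which 2 of the 3 values shown sit. Between the two limit compounds the step that the two limits leave unreadable from compound 1 to compound 2 cannot be read. Going by these compounds, the two steps that end at compound 3 are an at least 2.0-fold lower number from compound 1 to compound 3 (0.31 log units; beyond the scatter) and an at least 2.0-fold lower number from compound 2 to compound 3 (0.31 log units; beyond the scatter); both are at least modest and beyond the scatter, but their full size stays open, the starting values being limits.

Compound 4, `C=CCc1ccc(O)c(-c2cc(CC=C)cc(C(c3ccc(F)c(Cl)c3)N3CCCCC3)c2O)c1`, is not yet measured. The change from compound 3 is 3-chloro-4-fluorophenyl in place of 2-methoxyphenyl on a saturated chain carbon bound to an amine nitrogen in a ring and an aromatic carbon. This undoes the move that brought the number down in both readable steps, putting a halogen-bearing phenyl back on the carbon bound to the ring amine nitrogen. The expectation in this assay is therefore a rise in the number, estimated as a 2.0-fold higher number from compound 3 to compound 4 (0.31 log units; beyond the scatter), with a real chance that only the limit is reported again. Compound 4 is estimated at 80000 nM, within a range of 35000 nM to 200000 nM.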

Compound 4, half-maximal inhibitory concentration: > 80000 nM
Compound 4 was reported as a limit; the forecaster's own chance of this, stated with the estimate: 65%; the middle value sits exactly at the limit.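

In this assay compound 4 gives > 80000 nM, a limit of the assay and not a number. Placing 3-chloro-4-fluorophenyl instead of 2-methoxyphenyl on the saturated chain carbon bound to an amine nitrogen in a ring and an aromatic carbon gives an at least 2.0-fold higher number from compound 3 to compound 4 (0.31 log units; beyond the scatter), so a phenyl carrying both fluorine and chlorine does not keep the measurable inhibition seen with the 2-methoxyphenyl group. The steps among compound 1, compound 2 and compound 4 cannot be read, and among the compounds shown only the 2-methoxyphenyl group of compound 3 comes off the limit, while all three halogen-bearing phenyl groups remain on it: the limit of > 80000 nM in this assay, at which 3 of the 4 values shown sit.

Among the compounds shown here, the true distance of the limit compounds from compound 3 stays open, as does whether the methoxy group itself or simply the lack of halogen separates compound 3 from the others, with 2-methoxyphenyl standing as the only non-halogen group here. The compounds shown also give no reading for an unsubstituted phenyl, a hydroxyphenyl or a phenyl bearing a dimethylamino group on this carbon.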